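Iodo for fluoro on the thiourea ring of compound 3

A few compounds are considered here, and "the series" means these few. Any claim that something is new, unique, unknown or untested is made for them only; others in the source may bear on it.

Compound 1, `NC(=O)c1c(NC(=O)c2ccccc2Cl)sc2c1CCN(Cc1ccccc1F)C2`: in a functional assay on HeLa cells (Homo sapiens) for antiproliferative activity, with a stated time of 24 h (on this read-out lower numbers stand for stronger inhibition and higher numbers for weaker inhibition), compound 1 gives > 50000 nM, which is a limit of the assay and not a number (the limit of > 50000 nM in this assay, at which 1 of the 3 values shown sits).
Compound 2, `NC(=O)c1c(NC(=O)c2ccccc2Cl)sc2c1CCN(Cc1ccc([N+](=O)[O-])cc1)C2`: in this assay compound 2 gives 46100 nM.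
Compound 3, `NC(=O)c1c(NC(=O)c2ccccc2Cl)sc2c1CCN(C(=S)Nc1ccccc1F)C2`: in this assay compound 3 gives 28700 nM.

All three share one core and differ only in the group on the amine nitrogen in the ring. Compound 3 sits close to compound 2, as the step of a 1.6-fold lower number from compound 2 to compound 3 (0.21 log units; within the scatter) shows. The steps of an at least 1.0-fold lower number from compound 1 to compound 2 (0.03 log units; that floor lies within the scatter) and an at least 1.7-fold lower number from compound 1 to compound 3 (0.24 log units; that floor lies within the scatter) start from a limit and are likewise within the scatter.

Compound 4, `NC(=O)c1c(NC(=O)c2ccccc2Cl)sc2c1CCN(C(=S)Nc1ccccc1I)C2`, is not yet measured. It differs from compound 3 by iodo in place of fluoro on an aromatic carbon. Among the measured compounds shown here, none of the measured steps swaps one halogen for another on this ring; each replaces the whole group on the ring nitrogen, and none moves the number beyond the scatter. The expectation for compound 4 is therefore no step beyond the scatter, a 1.1-fold lower number from compound 3 to compound 4 (0.06 log units; within the scatter). Compound 4 is estimated at 25000 nM, between 8000 nM and 80000 nM.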

Compound 4, half-maximal inhibitory concentration: 29000 nM
Beside the measured number, compound 4's estimate is 1.2-fold (0.06 log units) below it; measured number inside the range.
By their numbers in this assay, from the lowest: compounds 3, 4 and 2 (each within the scatter of the next). At a limit, above all of these: compound 1.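

Here one halogen replaces another on this ring for the first time, and in this assay the step is a 1.0-fold higher number from compound 3 to compound 4 (0.00 log units; within the scatter), so at this place, on an aromatic carbon ortho to a large group, fluoro and iodo cannot be told apart. The wider comparisons read the same way: a 1.6-fold lower number from compound 2 to compound 4 (0.20 log units; within the scatter), and an at least 1.7-fold lower number from compound 1 to compound 4 (0.23 log units; that floor lies within the scatter), which starts from a limit. Compound 1 stands at a limit, which is not a number: the limit of > 50000 nM in this assay, at which 1 of the 4 values shown sits.

Nothing shown tells why the two halogens give such matching numbers. Going by these compounds, it remains open whether an amine or a carboxylic acid at this place on the ring, or a urea in place of the thiourea, would give a step beyond the scatter.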